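A Branched Carboxy Chain on Compound 2

A few compounds are considered here, and "the series" means these few. Any claim that something is new, unique, unknown or untested is made for them only; others in the source may bear on it.

In a physicochemical assay for solubility, in phosphate buffer, at pH 7.2 (on this read-out lower numbers stand for lower solubility and higher numbers for higher solubility), compound 1 `COc1cc(C2CN(C(=O)c3cc(OC[C@@H](O)CO)ccn3)C2)ccc1OCc1ccc(C2CC2)cc1` gives 3100 nM and compound 2 `COc1cc(C2CN(C(=O)c3cc(OCCCC(=O)O)ccn3)C2)ccc1OCc1ccc(C2CC2)cc1` gives 1100 nM as the lower of the two numbers. Compound 3 `COc1cc(C2CN(C(=O)c3cc(OCCCC(C)(C)C(=O)O)ccn3)C2)ccc1OCc1ccc(C2CC2)cc1` has not been measured yet. It differs from compound 2 by 1-carboxy-1-methylethyl in place of carboxy on a saturated chain carbon, three bonds along the chain from an oxygen on an aromatic ring and it keeps the carboxy group of compound 2.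

Among the compounds with values here, only one measured step bears on this, and only loosely. That step is a 2.8-fold lower number from compound 1 to compound 2 (0.45 log units; beyond the scatter) and it counts as modest, though beyond the scatter. Within the data shown here, it put 2-carboxyethyl in place of 1,2-dihydroxyethyl, which is a different change from the one at hand, and no measured pair tests this new change directly. Among the measured compounds shown here, with that single step as the only guide to size, the expectation is a small downward move that may stay within the scatter, an estimated 1.6-fold lower number from compound 2 to compound 3 (0.20 log units; within the scatter) in this assay on this reasoning. For compound 3 the expected value is 700 nM with an estimated range of 250 nM to 2000 nM on this read-out.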

Compound 3, solubility: 11400 nM
For compound 3 the middle estimate is 16-fold (1.21 log units) below the measured one; measured number outside the range, above it.
By their numbers in this assay, from the lowest: compound 2; then compound 1; then compound 3.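

In this assay, within the data shown here, the end of this chain turns out to matter far more than the earlier compounds could show: with a carboxy group present in both compounds, replacing carboxy with 1-carboxy-1-methylethyl gives a 10-fold higher number from compound 2 to compound 3 (1.02 log units; beyond the scatter), a large step where the only earlier one was modest. The earlier pair might have suggested that a carboxy chain reads lower than the 1,2-dihydroxyethyl chain of compound 1, but that holds only for compound 2 and compound 3 goes against it, with a 3.7-fold higher number from compound 1 to compound 3 (0.57 log units; beyond the scatter). Nothing available explains why the number rises so sharply with this change.

The change lengthens the chain and adds branching in a single move, so these three compounds cannot say how much of the step belongs to the extra length and how much to the two methyl groups. A longer unbranched carboxy chain would separate the two, and an amine in place of the carboxy group on the same branched chain would ask whether the carboxy group is needed for the higher number at all.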